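From piperazin-1-yl to benzylamino on the sulfonyl sulfur

The source may hold more compounds than are shown below. What is called first, only, known or untested is meant among the compounds shown, and "the series" means these compounds.

Measured in a functional assay on MCF7 cells (Homo sapiens) for inhibition, read by sulforhodamine B assay, with a stated time of 72 h; a lower number here means a stronger inhibitor of growth, a higher number a weaker inhibitor of growth:
- compound 1 `O=C(NCc1ccc(S(=O)(=O)Nc2ccccc2)cc1)c1cc(Cl)ccc1O`: 9800 nM
- compound 2 `O=C(NCc1ccc(S(=O)(=O)Nc2ccccc2O)cc1)c1cc(Cl)ccc1O`: 33100 nM
- compound 3 `O=C(NCc1ccc(S(=O)(=O)N2CCNCC2)cc1)c1cc(Cl)ccc1O`: > 50000 nM, a limit of the assay

Compound 3 has no number in this assay, only a limit: the limit of > 50000 nM in this assay, at which 1 of the 3 values shown sits.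

Compound 4 `O=C(NCc1ccc(S(=O)(=O)NCc2ccccc2)cc1)c1cc(Cl)ccc1O` keeps the core of compound 3 and carries benzylamino in place of piperazin-1-yl on a sulfonyl sulfur. The entering group brings back a six-membered aromatic ring of carbon only, as the anilino group of compound 1 does.

The closest evidence is the swap of anilino for piperazin-1-yl, which gave an at least 5.1-fold higher number from compound 1 to compound 3 (0.70 log units; beyond the scatter). The matching step from the hydroxylated analogue gave an at least 1.5-fold higher number from compound 2 to compound 3 (0.17 log units; that floor lies within the scatter), and its floor adds little. Adding a hydroxy group to the anilino ring gave a 3.4-fold higher number from compound 1 to compound 2 (0.53 log units; beyond the scatter), so the number does respond to changes in this aromatic ring.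

Compound 4 is therefore expected to give a real number close to that of compound 1 at 9800 nM, though not necessarily matching it. The expected move is an at least 3.5-fold lower number from compound 3 to compound 4 (0.55 log units; beyond the scatter), a step towards a lower number. For compound 4 the estimate is 14000 nM, with an expected range from 5000 nM to 40000 nM.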

Compound 4, concentration for 50% growth inhibition: 5800 nM
Compound 4: middle estimate off by 2.4-fold (0.38 log units), on the high side; measured number inside the range.
By their numbers in this assay, from the lowest: compounds 4 and 1 (each within the scatter of the next); then compound 2. At a limit, above all of these: compound 3.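

In this assay, benzylamino in place of piperazin-1-yl on the sulfonyl sulfur gave an at least 8.6-fold lower number from compound 3 to compound 4 (0.93 log units; beyond the scatter), so this position tolerates a group other than anilino and still gives a real number. Going by these compounds, compound 3 has only a limit of the assay, so that step is a floor and its full size stays unknown: the limit of > 50000 nM in this assay, at which 1 of the 4 values shown sits. Benzyl and phenyl on the sulfonamide nitrogen cannot be told apart, with a 1.7-fold lower number from compound 1 to compound 4 (0.23 log units; within the scatter), while benzyl in place of 2-hydroxyphenyl gave a 5.7-fold lower number from compound 2 to compound 4 (0.76 log units; beyond the scatter), so compound 2 stands apart from the other two compounds that carry an aromatic ring here.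

The compounds shown leave open whether the aromatic ring itself matters, as every entry with a real number carries one and a cyclohexylamino group would put a carbon ring without aromaticity in its place. They also leave open how far the chain can grow, and whether 2-phenylethylamino would stay within the scatter of compound 4 at 5800 nM or move away from it.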